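Capping the ring amine of compound 1 with tert-butoxycarbonyl

The compounds below may be only part of what the source reports. "The series", "measured", "known", "first", "only" and "open" are said of these compounds alone.

Compound 1 `COc1ccc(Cn2cc(CSC(=S)N3CCNCC3)nn2)cc1` has no number in a functional assay on MGC-803 cells (Homo sapiens) for inhibition, read by MTT assay, with a stated time of 72 h; on this read-out lower numbers stand for stronger inhibition and higher numbers for weaker inhibition: its entry reads "not determined" (no result reported), so no result was reported for it. The same holds for compound 2 `S=C(SCc1cn(Cc2ccc(Cl)c(Cl)c2)nn1)N1CCNCC1`, whose entry in this assay likewise reads "not determined" (no result reported). Only compound 3 `S=C(SCc1cn(Cc2ccccc2Cl)nn1)N1CCNCC1` carries a value here, giving 45200 nM in this assay, a weak effect. Compound 4 `COc1ccc(Cn2cc(CSC(=S)N3CCN(C(=O)OC(C)(C)C)CC3)nn2)cc1` has not yet been measured in this assay. It differs from compound 1 by tert-butoxycarbonyl in place of hydrogen on an amine nitrogen in a ring. Within the data shown here, with no measured step to guide the size of this change, and only the weak value of compound 3 as a point of reference, compound 4 is expected to remain weak in this assay, with an estimated value of 40000 nM and a likely range from 10000 nM to 150000 nM.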

Compound 4, half-maximal inhibitory concentration: 22800 nM
Estimate against measurement, compound 4: 1.8-fold (0.24 log units) above; the range from low to high includes it.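

No step can be read between compound 1 and compound 4: compound 1 carries no number. On these data alone, what tert-butoxycarbonyl in place of hydrogen does to inhibition stays open. No supporting evidence bears on this result.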